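The source may hold more compounds than are shown below. What is called first, only, known or untested is meant among the compounds shown, and "the series" means these compounds.

Of the compounds shown here, three sharing one core have been measured so far. Compound 1, `C#CCSc1nc(Nc2ccccc2)c2ccncc2n1`, carries only hydrogen at the position that varies among them. In a functional assay on PC-3 cells (Homo sapiens) for inhibition, read by MTT assay, with a stated time of 72 h (a lower number here means a stronger inhibitor, a higher number a weaker inhibitor), compound 1 gives only a limit of the assay, > 80000 nM. Compound 2, `C#CCSc1nc(Nc2ccc(F)cc2)c2ccncc2n1`, gives 17300 nM in this assay, and compound 3, `C#CCSc1nc(Nc2ccc(Br)cc2)c2ccncc2n1`, gives 26000 nM in this assay. Of the two numbers shown, compound 3 has the higher one, though its gap to compound 2 lies within the scatter. The steps of an at least 4.6-fold lower number from compound 1 to compound 2 (0.66 log units; beyond the scatter) and an at least 3.0-fold lower number from compound 1 to compound 3 (0.48 log units; beyond the scatter) both run beyond the scatter, whereas the step of a 1.5-fold higher number from compound 2 to compound 3 (0.18 log units; within the scatter) does not.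

Compound 4, `C#CCSc1nc(Nc2ccc(OC)cc2)c2ccncc2n1`, has not yet been measured in this assay. It differs from compound 3 by methoxy in place of bromo on an aromatic carbon. Among the compounds with values here, no measured step swaps bromo for methoxy; the steps that bear on it are those placing fluoro or bromo where compound 1 has hydrogen, both of which lowered the number beyond the scatter, and the swap between fluoro and bromo, which stayed within it. Since the two substituted compounds gave similar numbers, compound 4 is expected to stay near compound 3, with an estimated step of a 1.3-fold lower number from compound 3 to compound 4 (0.11 log units; within the scatter) inside the scatter. Compound 4 is therefore expected to give 20000 nM in this assay, within a range from 7000 nM to 60000 nM.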

Compound 4, half-maximal inhibitory concentration: 15100 nM
Estimate against measurement, compound 4: 1.3-fold (0.12 log units) above, and the stated range covers the measured number.
By their numbers in this assay, from the lowest: compounds 4, 2 and 3 (each within the scatter of the next). At a limit, above all of these: compound 1.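

Methoxy in place of hydrogen gives an at least 5.2-fold lower number from compound 1 to compound 4 (0.72 log units; beyond the scatter), so the lowering seen with fluoro and bromo at this position also appears with a group that is not a halogen and that brings in a hydrogen-bond acceptor. Neither a 1.7-fold lower number from compound 3 to compound 4 (0.24 log units; within the scatter) nor a 1.1-fold lower number from compound 2 to compound 4 (0.06 log units; within the scatter) leaves the scatter, so fluoro, bromo and methoxy cannot be told apart in this assay, even though the change from bromo to methoxy replaces a single bromine with a carbon and an oxygen. The true size of the step from hydrogen to methoxy cannot be stated, because compound 1 gives only a limit and not a number: the limit of > 80000 nM in this assay, at which 1 of the 4 values shown sits.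

The compounds shown leave open whether an amine, a carboxylic acid or a longer chain such as butoxy on this aromatic carbon would give a number that differs beyond the scatter from those of compounds 2, 3 and 4. They also leave open whether methoxy would give a similar result on another carbon of the same six-membered aromatic ring, since every substituent shown sits para to a large group.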